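Fluorine Walk on a Fused Ring of a Glutamate Receptor Modulator

The compounds below may be only part of what the source reports. "The series", "measured", "known", "first", "only" and "open" are said of these compounds alone.

Measured compounds:
compound 1 `Fc1cc(Cl)ccc1-c1ccc(Cn2nnc3ccccc32)cn1` gives 50 nM
compound 2 `Fc1cc(Cl)ccc1-c1ccc(Cn2nnc3c(F)cccc32)cn1` gives 27 nM
compound 3 `Fc1ccc2c(c1)nnn2Cc1ccc(-c2ccc(Cl)cc2F)nc1` gives 68 nM

In a functional assay on cells for positive allosteric modulation of metabotropic glutamate receptor 2 (Homo sapiens), read by fluorescence and calcium flux, with a stated time of 30 min (on this read-out lower numbers stand for an effect already at smaller amounts and higher numbers for an effect only at larger amounts of compound), compound 1 stands second highest of the three numbers; compound 2 sits closest below it and compound 3 closest above, and both lie within the scatter of compound 1. Compound 4 `Fc1ccc2nnn(Cc3ccc(-c4ccc(Cl)cc4F)nc3)c2c1` has not yet been measured. It differs from compound 1 by fluoro in place of hydrogen on an aromatic carbon.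

Within the data shown here, two measured steps bear on this change, each of them a fluoro in place of hydrogen on an aromatic carbon of the same fused system, only at a different carbon. The step of a 1.9-fold lower number from compound 1 to compound 2 (0.27 log units; within the scatter) and the step of a 1.4-fold higher number from compound 1 to compound 3 (0.13 log units; within the scatter) both stayed within the scatter. On that basis a single fluorine added to this fused ring is expected to move the number in this assay little, if at all, and no direction can be called from the two steps, since one went down and the other up.

For compound 4 the expectation is therefore a step of a 1.1-fold lower number from compound 1 to compound 4 (0.05 log units; within the scatter), not beyond the scatter. Compound 4 is estimated at 45 nM, with a range from 20 nM to 110 nM.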

Compound 4, half-maximal effective concentration: 86 nM
Compound 4: the middle estimate sits 1.9-fold (0.28 log units) below what was measured; the range from low to high includes it.
By their numbers in this assay, from the lowest: compounds 2, 1, 3 and 4 (each within the scatter of the next, the first and the last beyond it).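

In this assay the fluoro at this carbon, meta to a fused ring and para to a fused ring, gives a 1.7-fold higher number from compound 1 to compound 4 (0.24 log units; within the scatter) and so adds a third carbon of the six-membered aromatic ring where fluoro in place of hydrogen leaves the number within the scatter of compound 1. Among these compounds, what the earlier compounds did not show is that the place of the fluoro can still separate two such compounds: compound 2 at 27 nM and compound 4 at 86 nM lie beyond the scatter of each other, although neither lies beyond the scatter of compound 1. Nothing available here speaks to what lies behind these numbers.

The compounds shown leave open whether a different group on these same carbons, such as a methoxy group, an amine or a carboxylic acid, would also stay within the scatter of compound 1. They also leave open whether two fluoro groups together on this ring would produce a step beyond the scatter, as each single fluoro shown here does not.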